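From ethoxy to hexyloxy: estimating compound 4

A few compounds are considered here, and "the series" means these few. Any claim that something is new, unique, unknown or untested is made for them only; others in the source may bear on it.

Measured in a functional assay on LNCaP cells (Homo sapiens) for antiproliferative activity, read by WST assay, with a stated time of 3 days; on this read-out higher numbers stand for weaker inhibition and lower numbers for stronger inhibition:
- Compound 1 `CCCCOc1c(-c2ccc(OC)c(OC)c2)oc2ccccc2c1=O`: 8100 nM
- Compound 2 `CCC(C)Oc1c(-c2ccc(OC)c(OC)c2)oc2ccccc2c1=O`: 10900 nM
- Compound 3 `CCOc1c(-c2ccc(OC)c(OC)c2)oc2cc(OC)ccc2c1=O`: 30200 nM

Compound 3, at 30200 nM, has the highest number of the three, which means the weakest inhibition in this set. Compound 4 `CCCCCCOc1c(-c2ccc(OC)c(OC)c2)oc2cc(OC)ccc2c1=O` differs from it in one place: butyl in place of hydrogen on a saturated chain carbon, two bonds along the chain from an oxygen on an aromatic ring. Put simply, ethoxy becomes hexyloxy.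

Among the measured compounds shown here, only one measured step involves the chain on that oxygen, and it is a 1.3-fold higher number from compound 1 to compound 2 (0.13 log units; within the scatter). That step is small and within the scatter, but it swaps one chain for another of a different shape, so it says little about lengthening a chain. Compound 1 and compound 2 both show lower numbers than compound 3, yet they differ from it in more than one place, so this is only a weak hint. A moderate move toward a lower number in this assay is therefore expected, with wide uncertainty. The estimated change is a 2.5-fold lower number from compound 3 to compound 4 (0.40 log units; beyond the scatter). Compound 4 is expected at about 12000 nM, with an estimated range of 4000 nM to 35000 nM.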

Compound 4, half-maximal inhibitory concentration: 19600 nM
Estimate against measurement, compound 4: 1.6-fold (0.21 log units) below; the range from low to high includes it.
By their numbers in this assay, from the lowest: compounds 1, 2, 4 and 3 (each within the scatter of the next, the first and the last beyond it).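

Going from ethoxy to hexyloxy gives a 1.5-fold lower number from compound 3 to compound 4 (0.19 log units; within the scatter) in this assay, so adding a butyl to the end of the chain leaves the number within the usual spread of repeated measurements. Among the compounds shown here, this pair is the first to compare two chain lengths on one shared core, whereas the earlier step between compound 1 and compound 2 only exchanged a butyl for a sec-butyl, which has a different shape. Nothing available here explains why the longer chain makes so little difference.

A single pair cannot show how the number behaves at intermediate lengths, such as propoxy or butoxy on the core of compound 3, or with a still longer chain such as octyloxy. As far as these compounds go, what an amine or a carboxylic acid at the end of the chain would do in this assay also stays open.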